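The compounds below may be only part of what the source reports. "The series", "measured", "known", "first", "only" and "open" are said of these compounds alone.

Measured in a functional assay on HT-29 cells (Homo sapiens) for inhibition, read by MTT assay, with a stated time of 3 days (a lower number here means a stronger inhibitor, a higher number a weaker inhibitor), are these compounds
Compound 1 `COc1ccccc1/C=C/CCCOc1cc(/C=C\c2cc(OC)c(OC)c(OC)c2)ccc1OC` gives 86000 nM
Compound 2 `COCOc1ccc(/C=C/CCCOc2cc(/C=C\c3cc(OC)c(OC)c(OC)c3)ccc2OC)cc1` gives 7000 nM

Compound 2 holds the lower of the two numbers in this assay and is the stronger inhibitor of the pair. Compound 3 `COc1ccc(/C=C\c2cc(OC)c(OC)c(OC)c2)cc1OCCC/C=C/c1ccc(F)cc1` is still unmeasured. The change fluoro in place of methoxymethoxy on an aromatic carbon puts fluoro in place of methoxymethoxy on an aromatic carbon, para to a large group. Within the data shown here, the one measured step bearing on this is a 12-fold lower number from compound 1 to compound 2 (1.09 log units; beyond the scatter) and it was large, beyond the scatter, with the 4-(methoxymethoxy)phenyl group as its entering group. Losing that group is therefore expected to move the number upward, though less far. An estimated 2.1-fold higher number from compound 2 to compound 3 (0.33 log units; beyond the scatter) is expected. Compound 3 is estimated at 15000 nM (range 4000 nM to 60000 nM).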

Compound 3, half-maximal inhibitory concentration: 98000 nM
Estimate against measurement, compound 3: 6.5-fold (0.82 log units) below; the measured number lies above the stated range.
By their numbers in this assay, from the lowest: compound 2; then compounds 1 and 3 (each within the scatter of the next).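

In this assay the step of a 14-fold higher number from compound 2 to compound 3 (1.15 log units; beyond the scatter) comes with fluoro in place of methoxymethoxy on an aromatic carbon, para to a large group, so 4-fluorophenyl does not keep the lower number of compound 2. The step of a 1.1-fold higher number from compound 1 to compound 3 (0.06 log units; within the scatter) lies within the scatter, leaving 4-fluorophenyl and 2-methoxyphenyl indistinguishable here. No measurement at hand explains the gap between methoxymethoxy and fluoro.

The compounds shown leave open whether a hydroxyl or a plain methoxy in that place would match methoxymethoxy. They also leave open how a longer chain would read.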